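Moving the chlorine within the amide-bound aromatic ring

The source may report more compounds than this note shows. Statements on the series, on what has been measured and on what is new or still open speak of the compounds shown alone.

Measured compounds:
Compound 1, `CCCCCCCCCCCCn1nnc(C(NC(=O)c2c(C(C)C)cccc2C(C)C)c2ccccc2)n1`: 810 nM
Compound 2, `CCCCCCCCCCCCn1nnc(C(NC(=O)c2ccc(F)cc2F)c2ccccc2)n1`: 490 nM
Compound 3, `CCCCCCCCCCCCn1nnc(C(NC(=O)c2ccc(Cl)cc2)c2ccccc2)n1`: 440 nM

All three share a core and differ only in the aromatic group on the carbonyl carbon. In an assay on microsomes from liver for inhibition of sterol O-acyltransferase 1 (Rattus norvegicus) (on this read-out higher numbers stand for weaker inhibition and lower numbers for stronger inhibition), compound 1 gives 810 nM, compound 2 gives 490 nM and compound 3 gives 440 nM. On these numbers compound 3 cannot be told apart from the others: a 1.8-fold lower number from compound 1 to compound 3 (0.27 log units; within the scatter) and a 1.1-fold lower number from compound 2 to compound 3 (0.05 log units; within the scatter), both within the scatter, as is a 1.7-fold lower number from compound 1 to compound 2 (0.22 log units; within the scatter).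

Compound 4, `CCCCCCCCCCCCn1nnc(C(NC(=O)c2cccc(Cl)c2)c2ccccc2)n1`, has not yet been measured. It differs from compound 3 in one place: 3-chlorophenyl in place of 4-chlorophenyl on a carbonyl carbon. The same atoms are present, joined differently.

Among the compounds with values here, the steps that bear on this are the three above, since each swaps the aromatic group on the carbonyl carbon, and none moved the number beyond the scatter. Changing a chlorine into fluorines or into two isopropyl groups made no clear difference, so shifting the chlorine within the ring is expected to make none either. The expected step is a 1.1-fold higher number from compound 3 to compound 4 (0.06 log units; within the scatter). Compound 4 is estimated at 500 nM in this assay, most likely between 200 nM and 1300 nM.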

Compound 4, half-maximal inhibitory concentration: 250 nM
Beside the measured number, compound 4's estimate is 2.0-fold (0.30 log units) above it; the measured number falls inside the stated range.
By their numbers in this assay, from the lowest: compounds 4, 3, 2 and 1 (each within the scatter of the next, the first and the last beyond it).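

In this assay, moving the chlorine by putting 3-chlorophenyl in place of 4-chlorophenyl on the carbonyl carbon gives a 1.8-fold lower number from compound 3 to compound 4 (0.25 log units; within the scatter) and so does not separate the two isomers, and 3-chlorophenyl in place of 2,4-difluorophenyl gives a 2.0-fold lower number from compound 2 to compound 4 (0.29 log units; within the scatter) with the same outcome. Within the data shown here, what the earlier compounds did not show comes from 3-chlorophenyl in place of 2,6-diisopropylphenyl, which gives a 3.2-fold lower number from compound 1 to compound 4 (0.51 log units; beyond the scatter) and is the first step at this position to clear the scatter, although only modestly, so the aromatic group here can matter even though neighbouring members cannot be told apart. Nothing shown here explains that gap between the two ends of the series.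

The compounds shown leave open what 2-chlorophenyl, plain phenyl or 3-methoxyphenyl would give on the same carbonyl carbon, and so whether the chlorine's place in the ring matters at all. They also leave open whether a ring carrying an amine or a carboxylic acid would be tolerated, and whether the modest step seen with 3-chlorophenyl would survive a change to the long chain on the shared core.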